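The source may report more compounds than this note shows. Statements on the series, on what has been measured and on what is new or still open speak of the compounds shown alone.

In an ADME assay on L02 cells (Homo sapiens) for cytotoxicity, read by MTT assay, with a stated time of 48 h (a lower number here means a stronger inhibitor, a higher number a weaker inhibitor), compound 2 `O=C(OC[C@H]1CN(c2ccc(-n3cc(-c4ccccn4)cn3)c(F)c2)C(=O)O1)c1ccccc1` is reported only at the limit of the assay, > 400 ug/mL, which is a limit and not a measured number (the limit of > 400 ug/mL in this assay, at which 1 of the 2 values shown sits). Compound 1 `CCN1CCN(C[C@H]2CN(c3ccc(-n4cc(-c5ccccn5)cn4)c(F)c3)C(=O)O2)CC1` gives a measured value in this assay of 99 ug/mL. Within the data shown here, the single measured step, an at least 4.0-fold higher number from compound 1 to compound 2 (0.60 log units; beyond the scatter), describes a change at a different part of the shared core from the one now considered, so it gives no direct guide to the step ahead. Compound 3 `CNC(=O)[C@H]1CN(c2ccc(-n3cc(-c4ccccn4)cn3)c(F)c2)C(=O)O1` differs from compound 2 by methylcarbamoyl in place of (benzoyloxy)methyl on a saturated ring carbon. Among the measured compounds shown here, no measured step covers this exchange; with compound 2 already resting at the limit, the expectation for compound 3 is a number that again stays high, an expected step of a number no higher from compound 2 to compound 3 (the limit leaves the size open) with a fair chance that the assay once more reports only a limit. Compound 3 is estimated at 400 ug/mL, within a range from 150 ug/mL to 800 ug/mL.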

Compound 3, half-maximal inhibitory concentration: 217 ug/mL
Beside the measured number, compound 3's estimate is 1.8-fold (0.27 log units) above it; the measured number falls inside the stated range.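

With methylcarbamoyl on this saturated ring carbon, this assay returns a measured number rather than a limit, so this position can now be compared on firmer ground. Exchanging (4-ethylpiperazin-1-yl)methyl for methylcarbamoyl gives a 2.2-fold higher number from compound 1 to compound 3 (0.34 log units; beyond the scatter), while exchanging (benzoyloxy)methyl for it gives an at least 1.8-fold lower number from compound 2 to compound 3 (0.26 log units; that floor lies within the scatter). This second step has no fixed size, and a real difference cannot be claimed, because compound 2 is reported only as a limit: the limit of > 400 ug/mL in this assay, at which 1 of the 3 values shown sits.

Three groups on one ring carbon cannot show which feature of each group matters, since they differ in size, ring content and hydrogen-bond counts together. From the compounds shown here alone, whether an aminomethyl group, a carboxylic acid or a longer amide chain here would read nearer compound 1 or compound 3 remains open.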